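From Cyclohexyl Amide to an Aryl Amide on a Shared Core

This account rests on a few compounds, and the source may have more. Where it says the series, first, only, none or still open, it means among the compounds named here.

Of the compounds shown here, three on the same core have been measured in a functional assay on QGY7701 cells (Homo sapiens) for cytotoxicity, read by MTT assay, with a stated time of 24 h; on this read-out lower numbers stand for stronger inhibition and higher numbers for weaker inhibition. Compound 1 `C=CC1=C(C(=O)NC2CCCCC2)C(c2ccc(OC)cc2)OC1` gives only a limit of the assay, > 100000 nM, and not a number. Compound 2 `C=CC1=C(C(=O)NCCC)C(c2ccc(OC)c(OC)c2)OC1` likewise gives only a limit, > 100000 nM. Among the compounds with values here, compound 3 `C=CC1=C(C(=O)NCc2ccc(C)cc2)C(c2ccc(F)cc2)OC1` is the one compound with a number, giving 62100 nM in this assay. Compound 1 thus sits at the limit of > 100000 nM in this assay, at which 2 of the 3 values shown sit, so its true potency is not known; it is only weak enough to fall outside the measured window, as compound 2 also does.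

Compound 4 `C=CC1=C(C(=O)Nc2ccc(C)cc2)C(c2ccc(OC)cc2)OC1` differs from compound 1 in one place: 4-methylphenyl in place of cyclohexyl on an amide-type nitrogen. Within the data shown here, no pair of measured compounds shows this change on its own, and compound 3 changes two places at once relative to compound 1, so it gives no clean guide. With both neighbours of compound 1 at or near the edge of the window, no step beyond the scatter is expected, although a modest move toward stronger inhibition cannot be ruled out. The step of an at least 1.2-fold lower number from compound 1 to compound 4 (0.09 log units; that floor lies within the scatter) is therefore expected to be small. Compound 4 is estimated at 80000 nM, within a range from 25000 nM to 250000 nM, with a real chance that this assay again reports only a limit.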

Compound 4, half-maximal inhibitory concentration: > 100000 nM
Compound 4 gave a limit, no number; the forecaster's own chance of this, stated with the estimate: 50%; middle value at least 1.2-fold (0.09 log units) away from the limit.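

In this assay compound 4 gives > 100000 nM, a limit of the assay and not a number. Compound 1 also stops at a limit, so no step between compound 1 and compound 4 can be read: the limit of > 100000 nM in this assay, at which 3 of the 4 values shown sit.

From the compounds shown here alone, what stays open is whether 4-methylphenyl in place of cyclohexyl on an amide-type nitrogen changes the result in this assay at all.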